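Chloro for Fluoro: One Step on Two Cores

The compounds below may be only part of what the source reports. "The series", "measured", "known", "first", "only" and "open" are said of these compounds alone.

Measured in a functional assay on A549 cells (Homo sapiens) for antiproliferative activity, read by MTT assay, with a stated time of 48 h; on this read-out higher numbers stand for weaker inhibition and lower numbers for stronger inhibition:
compound 1, `O=C(/C=C\Nc1ccc(F)cc1)c1cn(-c2ccccc2)nc1-c1ccccc1`, gives 4670 nM;
compound 2, `O=C(/C=C\Nc1ccc(Cl)cc1)c1cn(-c2ccccc2)nc1-c1ccccc1`, gives 14100 nM;
compound 3, `COc1cc(-c2nn(-c3ccccc3)cc2C(=O)/C=C\Nc2ccc(F)cc2)cc(OC)c1OC`, gives 15600 nM.

Compound 2 differs from compound 1 by chloro in place of fluoro on an aromatic carbon, and the step read a 3.0-fold higher number from compound 1 to compound 2 (0.48 log units; beyond the scatter). Compound 4, `COc1cc(-c2nn(-c3ccccc3)cc2C(=O)/C=C\Nc2ccc(Cl)cc2)cc(OC)c1OC`, has not yet been measured in this assay; it differs from compound 3 by chloro in place of fluoro on an aromatic carbon, at the same place, so it is the same change. How the core of compound 1 and the core of compound 3 differ is not broken down here. Compound 3 already sits at the high end of the three numbers. Because the earlier step of a 3.0-fold higher number from compound 1 to compound 2 (0.48 log units; beyond the scatter) was modest though beyond the scatter, a step of a 2.1-fold higher number from compound 3 to compound 4 (0.31 log units; beyond the scatter) is expected on the other core. Compound 4 is therefore estimated at 32000 nM, expected between 13000 nM and 80000 nM.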

Compound 4, half-maximal inhibitory concentration: 8670 nM
Beside the measured number, compound 4's estimate is 3.7-fold (0.57 log units) above it; the measured number lies below the stated range.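

In this assay, putting chloro in place of fluoro on the core of compound 3 gave a 1.8-fold lower number from compound 3 to compound 4 (0.26 log units; within the scatter), so this pair cannot be told apart. The change therefore did not carry over from one core to the other with the same result: the same change on two cores in this assay, a 3.0-fold higher number (0.48 log units; beyond the scatter) from compound 1 to compound 2 and a 1.8-fold lower number (0.26 log units; within the scatter) from compound 3 to compound 4, 5.4-fold (0.74 log units) apart, beyond the scatter of two such steps. For the compounds shown here, this shows that a step read on the core of compound 1 is a poor guide to the core of compound 3, but with only two pairs it gives neither a reason for the gap nor a rule for other cores.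

Still open, on these data alone, is whether a bromo or methyl group at the same place would also behave differently on the two cores. Also open, as far as these compounds go, is which part of the core of compound 3 sets it apart from the core of compound 1.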